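This account rests on a few compounds, and the source may have more. Where it says the series, first, only, none or still open, it means among the compounds named here.

Compound 1 (`CCCc1ccccc1OCCCOc1cc2oc(C(=O)O)cc(=O)c2cc1CCC`) gives 18 ug/mL in a functional assay on ileum (Cavia porcellus) for antagonist activity, with a stated time of 30 s (a lower number here means a stronger inhibitor, a higher number a weaker inhibitor), and compound 2 (`CCCc1ccccc1OCC(O)COc1ccc2c(=O)cc(C(=O)O)oc2c1`) gives 2 ug/mL as the lower of the two numbers, a gap beyond the scatter. Among the measured compounds shown here, compound 3 (`CCCc1ccccc1OCC(O)COc1cc2oc(C(=O)O)cc(=O)c2cc1CCC`) differs from compound 2 by propyl in place of hydrogen on an aromatic carbon as the one change: propyl in place of hydrogen on an aromatic carbon. For the measured compounds named here, no measured pair isolates this change, so only a small fall in the number is expected in this assay and possibly none beyond the scatter. The estimated move is a 1.3-fold lower number from compound 2 to compound 3 (0.12 log units; within the scatter) on this thin basis. Compound 3 is estimated at 1.5 ug/mL with an expected range from 0.3 ug/mL to 8 ug/mL for now.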

Compound 3, half-maximal inhibitory concentration: 1.6 ug/mL
For compound 3 the middle estimate is 1.1-fold (0.03 log units) below the measured one; the measured number falls inside the stated range.
By their numbers in this assay, from the lowest: compounds 3 and 2 (each within the scatter of the next); then compound 1.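

In this assay propyl in place of hydrogen on the aromatic carbon gives a 1.3-fold lower number from compound 2 to compound 3 (0.10 log units; within the scatter) and so leaves no shift beyond the scatter at this position. Hydroxy in place of hydrogen on the saturated chain carbon gives an 11-fold lower number from compound 1 to compound 3 (1.05 log units; beyond the scatter) and is the first single-place change in the series to show a large step. No supporting measurement bears on the reason for either step. Open, from the compounds shown here alone, is whether a longer chain on the aromatic carbon would also leave the number within the scatter. Also open, going by these compounds, is whether an amine in place of the hydroxy on the chain carbon would keep the large step.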